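Swapping a furan for a thiazole on a shared core

This account rests on a few compounds, and the source may have more. Where it says the series, first, only, none or still open, it means among the compounds named here.

The two measured compounds:
compound 1 `Cc1cccc(-c2ccccc2OCC2=NCCN2)n1` – a limit in this assay, < 100000 nM
compound 2 `c1coc(-c2ccccc2OCC2=NCCN2)c1` – a limit in this assay, < 100000 nM

The readout is a functional assay for activation of Alpha-1D adrenergic receptor (Homo sapiens), read by calcium flux; a higher number here means that more compound is needed for the effect, a lower number that less compound is needed. For compound 2 the value is a limit, not a number, so all that is known is that the half-maximal effective concentration of compound 2 lies on the far side of that limit. The same holds for the second value shown, so compound 2 stands exactly where every measured compound stands: the limit of < 100000 nM in this assay, at which 2 of the 2 values shown sit. No real number separates the two compounds, and no ordering between them can be read from these data.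

Compound 3 `c1ccc(-c2nccs2)c(OCC2=NCCN2)c1` differs from compound 2 in one place: 1,3-thiazol-2-yl in place of furan-2-yl on an aromatic carbon. Among the compounds with values here, no measured step exists to calibrate this change, and the two measured values give only a ceiling. The step from compound 2 to compound 3, a step that the limit leaves unreadable from compound 2 to compound 3, is therefore expected to stay within the usual scatter rather than move the value in a clear direction. Compound 3 is estimated at 10000 nM, with a plausible range from 500 nM to 100000 nM, and a real chance that the assay again reports only a limit.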

Compound 3, half-maximal effective concentration: 31.6 nM
Compound 3: the middle estimate sits 320-fold (2.50 log units) above what was measured; the measured number lies below the stated range.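

Within the data shown here, no step between compound 2 and compound 3 can be read, because compound 2 is known only as a limit and the size of any change from it stays unknown: the limit of < 100000 nM in this assay, at which 2 of the 3 values shown sit. The compounds shown leave open how far compound 2 lies from compound 3, and whether 1,3-thiazol-2-yl in place of furan-2-yl truly shifts the value beyond the usual scatter.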